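The compounds below may be only part of what the source reports. "The series", "measured", "known", "first", "only" and "open" are said of these compounds alone.

Compound 1 `O=C1NC2(C3=C(C(=O)C4C=CC=CC4C3=O)c3ccccc32)c2ccccc21`: 6880 nM
Compound 2 `O=C1NC2(C3=C(C(=O)C4C=CC=CC4C3=O)c3ccccc32)c2cc(Cl)c(Cl)cc21`: 3010 nM

In a functional assay on MDA-MB-231 cells (Homo sapiens) for antiproliferative activity, read by MTT assay, with a stated time of 48 h (on this read-out higher numbers stand for weaker inhibition and lower numbers for stronger inhibition), compound 1 has the higher of the two numbers, and compound 2 lies lower by more than the usual scatter. Compound 3 `O=C1NC2(C3=C(C(=O)C4C=CC=CC4C3=O)c3cc(Cl)ccc32)c2ccccc21` differs from compound 1 in one place: chloro in place of hydrogen on an aromatic carbon. Going by the values given here, no step between measured compounds bears directly on this change, so only a small move towards stronger inhibition is expected, of a size close to the scatter. The expected shift is a 1.4-fold lower number from compound 1 to compound 3 (0.16 log units; within the scatter). The estimated value for compound 3 is 4800 nM, with an expected range from 2200 nM to 10500 nM.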

Compound 3, half-maximal inhibitory concentration: 17600 nM
Compound 3: middle estimate off by 3.7-fold (0.56 log units), on the low side; measured number above the stated range.
By their numbers in this assay, from the lowest: compound 2; then compound 1; then compound 3.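

In this assay, chloro in place of hydrogen on this aromatic carbon gives a 2.6-fold higher number from compound 1 to compound 3 (0.41 log units; beyond the scatter) and so moves the series towards weaker inhibition, by more than the usual scatter. Going by these compounds alone, this is the first change in a single place that can be read here, and at this position chloro does not lower the number. Nothing available explains the direction of this step.

As far as these compounds go, whether fluoro, methoxy or an amine at this carbon would move the number the same way remains open. So does the effect of a single chloro on other aromatic carbons of the shared core.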